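Chain extension on the amide side of compound 3

The source may report more compounds than this note shows. Statements on the series, on what has been measured and on what is new or still open speak of the compounds shown alone.

Compound 1 `CCCCCCCCCCCCNC(=O)[C@@H](NC(=O)c1ccccc1)[C@@H](C)O` is the reference of the series. In a functional assay on SiHa cells (Homo sapiens) for cytotoxicity, read by MTT assay, with a stated time of 48 h (a lower number here means a stronger inhibitor, a higher number a weaker inhibitor), compound 1 gives 63900 nM. Compound 2 `CCCCCCCCCCCCNC(=O)[C@@H](NC(=O)c1cc2ccccc2n1C)[C@@H](C)O` carries 1-methyl-1H-indol-2-yl in place of phenyl on the carbonyl carbon. For compound 2 only a limit is recorded, > 200000 nM. Compound 3 `C/C=C/C=C/C(=O)N[C@H](C(=O)NCCCCCCCCCCCC)[C@@H](C)O` carries penta-1,3-dien-1-yl on the carbonyl carbon. For compound 3 too only a limit is recorded, > 200000 nM. The step of an at least 3.1-fold higher number from compound 1 to compound 2 (0.49 log units; beyond the scatter) and the step of an at least 3.1-fold higher number from compound 1 to compound 3 (0.49 log units; beyond the scatter) both read as losses, while the step that the two limits leave unreadable from compound 2 to compound 3 cannot be sized, because of the limit of > 200000 nM in this assay, at which 2 of the 3 values shown sit. Compound 3 thus stands at the limit of this assay, with one other value sitting there as well, and its position against compound 2 is unresolved.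

Compound 4 `C/C=C/C=C/C(=O)N[C@H](C(=O)NCCCCCCCCCCCCCC)[C@@H](C)O` differs from compound 3 by ethyl in place of hydrogen on a saturated chain carbon, ten or more bonds along the chain from an amide-type nitrogen. Among the compounds with values here, none of the measured steps touches this chain; all three alter the group on the carbonyl carbon, so none bears directly on the present change. In this assay no step beyond the scatter is expected in either direction. Since compound 3 sits at a limit, compound 4 is expected to sit at or near that limit too. The estimate for compound 4 is 250000 nM with a range from 60000 nM to 1000000 nM. This corresponds to an expected step that the limit leaves unreadable from compound 3 to compound 4.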

Compound 4, half-maximal inhibitory concentration: > 200000 nM
Compound 4 gave a limit, no number; the forecaster's own chance of this, stated with the estimate: 75%; the middle value is on the limit's open side.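

In this assay compound 4 gives > 200000 nM, which is a limit and not a number, so no size can be read for its step from compound 3, which also sits at a limit: the limit of > 200000 nM in this assay, at which 3 of the 4 values shown sit.

The compounds shown leave open whether ethyl in place of hydrogen on this chain changes the read-out, and how compound 2, compound 3 and compound 4 rank against one another.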